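Series notes: amide variants on a shared core, cytotoxicity

This account rests on a few compounds, and the source may have more. Where it says the series, first, only, none or still open, it means among the compounds named here.

Measured compounds in a toxicity assay on HepG2 2.2.15 cells (Homo sapiens) for cytotoxicity, read by CCK-8 assay, with a stated time of 8 days; on this read-out lower numbers stand for higher toxicity in this test and higher numbers for lower toxicity in this test:
compound 1 `CC(C)Cc1nn(-c2nccs2)cc1C(=O)NCc1cccc(F)c1`: > 100000 nM (a limit of the assay)
compound 2 `CC(C)Cc1nn(-c2nccs2)cc1C(=O)NCc1ccc(C(F)(F)F)cc1`: > 100000 nM (a limit of the assay)
compound 3 `CC(C)Cc1nn(-c2nccs2)cc1C(=O)NCc1ccc(O)cc1`: > 100000 nM (a limit of the assay)

Compound 3 stands at a limit, as do the other two values shown, so none of the three can be ranked. The steps a step that the two limits leave unreadable from compound 1 to compound 3 and a step that the two limits leave unreadable from compound 2 to compound 3 are therefore unreadable in size and direction; all three sit at the limit of > 100000 nM in this assay, at which 3 of the 3 values shown sit.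

Compound 4 `COc1ccc(CNC(=O)c2cn(-c3nccs3)nc2CC(C)C)cc1` differs from compound 3 by methyl in place of hydrogen on an oxygen on an aromatic ring. Among the measured compounds shown here, no measured step bears on a change of this kind, and the steps that reach compound 3 give no size. With every value shown at the limit, compound 4 is expected to give a limit as well, and the estimated step of a number no higher from compound 3 to compound 4 (the limit leaves the size open) is taken as none beyond the scatter. The estimate for compound 4 is 100000 nM, within 50000 nM to 200000 nM.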

Compound 4, half-maximal cytotoxic concentration: > 100000 nM
Compound 4: no number, only a limit (the forecaster's own chance of this, stated with the estimate: 85%); the middle value lies on the limit itself.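

No step can be read from compound 4 to compound 1, compound 2 or compound 3 in this assay, as each value is a limit: the limit of > 100000 nM in this assay, at which 4 of the 4 values shown sit.

The compounds shown leave open what amide change, if any, on the shared core would give a measurable value in this assay.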